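This account rests on a few compounds, and the source may have more. Where it says the series, first, only, none or still open, it means among the compounds named here.

Measured so far:
Compound 1 `CCC1(c2cccc(Br)c2)ON=C(c2ccccc2Cl)O1`: in an ADME assay on HEK293 cells (Homo sapiens) for cytotoxicity, read by MTT assay, with a stated time of 44 h (a higher number here means a weaker inhibitor, a lower number a stronger inhibitor), compound 1 gives > 100000 nM, which is a limit of the assay and not a number.
Compound 2 `Clc1ccc(C2=NOC(c3ccc(Cl)c(Cl)c3)O2)cc1`: in this assay compound 2 gives > 100000 nM, again a limit and not a number.

Compound 2 therefore stands at the limit, with no number to place it on a scale; both values shown sit at the limit of > 100000 nM in this assay, at which 2 of the 2 values shown sit. Compound 3 `Clc1ccc(C2=NOC(c3ccc(Cl)cc3)O2)cc1` differs from compound 2 by hydrogen in place of chloro on an aromatic carbon. Among the measured compounds shown here, no step between measured compounds is available, so the size of this change in this assay has no precedent. Because both measured compounds sit at the limit of > 100000 nM in this assay, at which 2 of the 2 values shown sit, the step expected in this assay is a number no higher from compound 2 to compound 3 (the limit leaves the size open), none beyond the scatter. For compound 3 the estimate in this assay is 100000 nM, with a range from 30000 nM to 300000 nM, and most probably the assay will again report only a limit.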

Compound 3, half-maximal inhibitory concentration: > 100000 nM
Compound 3 gave a limit, no number (the forecaster's own chance of this, stated with the estimate: 80%); the middle value sits exactly at the limit.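

The step from compound 2 to compound 3, hydrogen in place of chloro on an aromatic carbon, cannot be read, since both compounds give only limits: the limit of > 100000 nM in this assay, at which 3 of the 3 values shown sit.

The compounds shown leave open what any of them gives in this assay as an actual number and what size this step has.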